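Replacing Nitro with Chloro in Compound 1

The source may hold more compounds than are shown below. What is called first, only, known or untested is meant among the compounds shown, and "the series" means these compounds.

In a functional assay on the whole organism with Mus musculus as the target (on this read-out lower numbers stand for an effect already at smaller amounts and higher numbers for an effect only at larger amounts of compound), compound 1 (`COc1cc2c(cc1OC)C(c1ccc([N+](=O)[O-])cc1)=NN=C(S)C2`) gives 69.8 umol/kg as its half-maximal dose. Compound 2 (`COc1cc2c(cc1OC)C(c1ccc(Br)cc1)=NN(C)C(=S)C2`) gives 60.4 umol/kg which lies within the usual scatter of compound 1. Compound 3 (`COc1cc2c(cc1OC)C(c1ccccc1)=NNC(=O)C2`) gives 31.8 umol/kg and so sits lower than compound 1 by more than that scatter. Compound 4 (`COc1cc2c(cc1OC)C(c1ccc(Cl)cc1)=NN=C(S)C2`) has not yet been measured. It carries chloro in place of nitro on an aromatic carbon, para to a large group (chloro in place of nitro on an aromatic carbon). Among the measured compounds shown here, no measured pair here differs in one place only, so nothing shows directly what this change does. The expected step of a 1.4-fold lower number from compound 1 to compound 4 (0.14 log units; within the scatter) is small, toward a lower number and within the scatter. For compound 4 the estimated dose is 50 umol/kg with an expected range from 22 umol/kg to 110 umol/kg around it.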

Compound 4, dose for half-maximal effect: 55 umol/kg
Estimate against measurement, compound 4: 1.1-fold (0.04 log units) below, within the range that was stated.
By their numbers in this assay, from the lowest: compounds 3, 4, 2 and 1 (each within the scatter of the next, the first and the last beyond it).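

Among the compounds shown here, compound 1 and compound 4 are the first pair here that differs in one place only, so the effect of this change in this assay can now be read directly: the step is a 1.3-fold lower number from compound 1 to compound 4 (0.10 log units; within the scatter). At this position, chloro and nitro cannot be told apart in this assay, even though chloro is the smaller group and has no hydrogen-bond acceptors. Nothing measured here explains this similarity. From the compounds shown here alone, it remains open whether an amine or a carboxylic acid at this position would shift the dose beyond the scatter.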